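Chloro for nitro in a trimethoxyphenyl chalcone series

The source may report more compounds than this note shows. Statements on the series, on what has been measured and on what is new or still open speak of the compounds shown alone.

Three chalcones sharing a trimethoxyphenyl core have been tested in a functional assay on cells (Erythrocyte, Rattus norvegicus) for inhibition, read by hemolysis, with a stated time of 1 h; a lower number here means a stronger inhibitor, a higher number a weaker inhibitor. Compound 1, `COc1cc(OC)c(C(=O)/C=C/c2cc(OC)c(OC)cc2OC)c(OC)c1`, gives 2.13 ug/mL in this assay. Compound 2, `COc1cc(OC)c(OC)cc1/C=C/C(=O)c1ccc([N+](=O)[O-])cc1`, gives 2.34 ug/mL. Compound 3, `COc1cc(OC)c(OC)cc1/C=C/C(=O)c1cccc(C(F)(F)F)c1`, gives 2.3 ug/mL. Compound 2 carries the largest of the three numbers, but its gaps to compound 3 and to compound 1 both lie within the scatter of repeated measurements, so the three cannot be told apart on these data.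

The next member is compound 4, `COc1cc(OC)c(OC)cc1/C=C/C(=O)c1ccc(Cl)cc1`, which differs from compound 2 in one place: chloro in place of nitro on an aromatic carbon. Within the data shown here, no step between two measured compounds isolates this change, so nothing in the set says how the hemolysis read-out responds to it. Since the three measured compounds, which differ widely on the ring that bears the change, all sit within the scatter of one another in this assay, the most reasonable expectation is that compound 4 again shows no step beyond the scatter. Compound 4 is therefore expected to give about 2.5 ug/mL in this assay, within a range of 1.2 ug/mL to 5 ug/mL. The step expected from this estimate is a 1.1-fold higher number from compound 2 to compound 4 (0.03 log units; within the scatter).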

Compound 4, half-maximal inhibitory concentration: 2.3 ug/mL
Estimate against measurement, compound 4: 1.1-fold (0.04 log units) above; measured number inside the range.
By their numbers in this assay, from the lowest: compounds 1, 3, 4 and 2 (each within the scatter of the next).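

In this assay, among these compounds, chloro in place of nitro on an aromatic carbon, para to a large group, gives a 1.0-fold lower number from compound 2 to compound 4 (0.01 log units; within the scatter), and this is the first step in the set that isolates a single change. At this position, a group of three heavy atoms with two hydrogen-bond acceptors and a single chlorine atom with no hydrogen-bond acceptors therefore cannot be told apart by the hemolysis read-out. No supporting measurement is available to explain this outcome.

Among the compounds shown here, with only this one step, it remains open whether any group at this position can shift the hemolysis read-out beyond the scatter, and an amine or a carboxylic acid in the same place would test this with a hydrogen-bond donor, which neither nitro nor chloro has. It is also open whether the same exchange would behave alike on the core of compound 1, or whether a bare aromatic carbon, with a hydrogen in place of nitro or chloro, would give a number within the scatter of those of the compounds shown here.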